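A few compounds are considered here, and "the series" means these few. Any claim that something is new, unique, unknown or untested is made for them only; others in the source may bear on it.

Working notes on the phenoxysulfonyl series.

Compound 1 `O=S(=O)(Oc1ccccc1)C1CC2OC1C(c1ccc(/C=C/c3cc(O)cc(O)c3)cc1)=C2c1ccc(O)cc1` is the reference point. In a functional assay on MCF7 cells (Homo sapiens) for antiproliferative activity, read by MTT assay, with a stated time of 72 h (a higher number here means a weaker inhibitor, a lower number a stronger inhibitor), compound 1 gives 20100 nM, the largest of the three numbers recorded so far, with the other two lying inside the scatter of it. Compound 2 `O=S(=O)(Oc1ccc(Br)cc1)C1CC2OC1C(c1ccc(/C=C/c3cc(O)cc(O)c3)cc1)=C2c1ccc(O)cc1`, carrying bromo in place of hydrogen on an aromatic carbon, gives 16900 nM in this assay; the step is a 1.2-fold lower number from compound 1 to compound 2 (0.08 log units; within the scatter). Compound 3 `O=S(=O)(Oc1ccc(O)cc1)C1CC2OC1C(c1ccc(/C=C/c3cc(O)cc(O)c3)cc1)=C2c1ccc(O)cc1`, carrying hydroxy in place of hydrogen on the same ring, gives 14100 nM; the step is a 1.4-fold lower number from compound 1 to compound 3 (0.15 log units; within the scatter), and between the two substituted phenoxy compounds it is a 1.2-fold lower number from compound 2 to compound 3 (0.08 log units; within the scatter). None of the three steps leaves the scatter, so substitution on the phenoxy ring has so far not moved the number.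

Compound 4 `O=S(=O)(Oc1cccc(Br)c1)C1CC2OC1C(c1ccc(/C=C/c3cc(O)cc(O)c3)cc1)=C2c1ccc(O)cc1` differs from compound 1 as bromo in place of hydrogen on an aromatic carbon. Among the compounds with values here, the only measured step that bears on it is the bromo entry of compound 2, a 1.2-fold lower number from compound 1 to compound 2 (0.08 log units; within the scatter), which stayed within the scatter. With nothing to suggest the 3-bromophenoxy placement behaves differently, no step beyond the scatter is expected in this assay. Compound 4 is therefore estimated at 17500 nM, with a range from 9000 nM to 34000 nM. The expected step is a 1.1-fold lower number from compound 1 to compound 4 (0.06 log units; within the scatter).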

Compound 4, half-maximal inhibitory concentration: 19800 nM
The estimate for compound 4 lay 1.1-fold (0.05 log units) below the measured number, and the stated range covers the measured number.
By their numbers in this assay, from the lowest: compounds 3, 2, 4 and 1 (each within the scatter of the next).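

In this assay the 3-bromophenoxy group of compound 4 gives a second bromo placement on the phenoxy ring, and adding bromo meta to a large group produces only a 1.0-fold lower number from compound 1 to compound 4 (0.01 log units; within the scatter). The two bromo placements are also not told apart, with a 1.2-fold higher number from compound 2 to compound 4 (0.07 log units; within the scatter), and the exchange of the hydroxy group of compound 3 for this bromo gives a 1.4-fold higher number from compound 3 to compound 4 (0.15 log units; within the scatter), so the earlier finding for a single placement now holds for both placements of bromo and all four phenoxy compounds sit at one level within the scatter. Nothing available explains why these changes on the ring leave the read-out so flat.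

The compounds shown carry only bromo and hydroxy on the phenoxy ring, so it remains open whether an amine, a carboxylic acid or a longer chain such as butoxy on this ring would give a step beyond the scatter. From the compounds shown here alone, it also remains open whether changes away from the phenoxy ring, on the shared core of compound 1, would move the number further than any change seen here.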